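The source may report more compounds than this note shows. Statements on the series, on what has been measured and on what is new or still open speak of the compounds shown alone.

Of the compounds shown here, two have been measured so far in an assay for inhibition of very long chain fatty acid elongase 6 (Homo sapiens); a lower number here means a stronger inhibitor, a higher number a weaker inhibitor. Compound 1 `O=C(Nc1ccc(F)cc1)OCC1(C(F)(F)F)OC(=O)Nc2ccc(Cl)cc21` gives 142 nM in this assay, the lowest of the two numbers; compound 2 `O=C1Nc2ccc(-n3cncn3)cc2C(CNC(=O)c2ccc(F)cc2)(C(F)(F)F)O1` gives 572 nM, and the gap between the two lies beyond the usual scatter. The unmeasured compound 3 `CCC1(COC(=O)Nc2ccc(F)cc2)OC(=O)Nc2ccc(Cl)cc21` differs from compound 1 in one place: ethyl in place of trifluoromethyl on a saturated ring carbon. Among the compounds with values here, no measured pair shows this change, so the expectation rests on compound 1 alone. For compound 3 a modest step toward a higher number is expected, a 2.1-fold higher number from compound 1 to compound 3 (0.32 log units; beyond the scatter), though a step within the scatter would not surprise. Compound 3 is thus expected to give about 300 nM in this assay, within a range from 100 nM to 900 nM.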

Compound 3, half-maximal inhibitory concentration: 2260 nM
For compound 3 the middle estimate is 7.5-fold (0.88 log units) below the measured one; measured number outside the range, above it.
By their numbers in this assay, from the lowest: compound 1; then compound 2; then compound 3.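

Ethyl in place of trifluoromethyl on this saturated ring carbon brings a 16-fold higher number from compound 1 to compound 3 (1.20 log units; beyond the scatter) in this assay, so the position is far from indifferent to the group it carries. Within this pair, trifluoromethyl gives the stronger inhibitor, and ethyl is a poor substitute for it. Nothing available explains the size of this step. From the compounds shown here alone, whether methyl, a single hydrogen or a longer chain at this carbon would land nearer compound 1 or compound 3 remains open. Also open, going by these compounds, is whether the same change would bring a step of similar size in compound 2.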